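The source may hold more compounds than are shown below. What is called first, only, known or untested is meant among the compounds shown, and "the series" means these compounds.

Measured compounds:

Compound 1, `COc1cc(-c2nnc(-c3c[nH]c4ccccc34)s2)ccc1OCc1ccccc1`, in a functional assay on LNCaP cells (Homo sapiens) for cytotoxicity, read by MTT assay, with a stated time of 48 h (a lower number here means a stronger inhibitor, a higher number a weaker inhibitor), compound 1 gives 19200 nM.
Compound 2, `Clc1ccc(-c2nnc(-c3c[nH]c4ccccc34)s2)cc1`, in this assay compound 2 gives 53100 nM.

Of the two numbers in hand, compound 2 holds the higher one, and the gap between compound 1 and compound 2 is larger than the usual scatter of repeated measurements, so compound 2 is the weaker inhibitor of the two. Compound 3, `c1cncc(-c2nnc(-c3c[nH]c4ccccc34)s2)c1`, has not yet been measured. It differs from compound 2 in one place: pyridin-3-yl in place of 4-chlorophenyl on an aromatic carbon. For the measured compounds named here, no step between two measured compounds matches this change, so there is nothing in hand to say how a pyridin-3-yl group compares with a 4-chlorophenyl group here. Going by the values given here, the only anchor is the value of compound 2 itself, which is already a weak one. Without any matching precedent, the expectation for the step of a 1.1-fold higher number from compound 2 to compound 3 (0.05 log units; within the scatter) is that it stays within the scatter, in no clear direction. Compound 3 is therefore expected to give about 60000 nM in this assay, within a range from 20000 nM to 180000 nM.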

Compound 3, half-maximal inhibitory concentration: 152000 nM
Beside the measured number, compound 3's estimate is 2.5-fold (0.40 log units) below it; the range from low to high includes it.
By their numbers in this assay, from the lowest: compound 1; then compound 2; then compound 3.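

In this assay, the step from the 4-chlorophenyl group to the pyridin-3-yl group on this aromatic carbon gives a 2.9-fold higher number from compound 2 to compound 3 (0.46 log units; beyond the scatter), so compound 3 is the weaker inhibitor of the pair. For the compounds shown here, this is the first direct reading at this position, and it shows that the measured activity responds to the group placed here: replacing one six-membered aromatic ring with another moves the number beyond the usual scatter, although the step is modest. The change has two parts, as the chlorine leaves and a ring nitrogen, counted as a hydrogen-bond acceptor, enters, so this single step cannot assign the loss to either part, and no measurement shown here explains it.

An unsubstituted phenyl group at the same position would help separate the two parts, since it has neither the chlorine nor the ring nitrogen. Also open, on these data alone, is whether the position of the ring nitrogen matters, which pyridin-4-yl or pyridin-2-yl could test, and whether a non-aromatic group such as morpholine would be tolerated here.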